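A Branched Chain End on Compound 3

A few compounds are considered here, and "the series" means these few. Any claim that something is new, unique, unknown or untested is made for them only; others in the source may bear on it.

Values measured in a toxicity assay on Hepa-1c1c7 cells (Mus musculus) for inhibition (on this read-out lower numbers stand for stronger inhibition and higher numbers for weaker inhibition), for each compound:
Compound 1 `CCCCC[C@H](O)C#CC#CCO` gives > 100000 nM as a limit of the assay, not a number
Compound 2 `CCCCC[C@H](O)C#CC#C[C@@H](O)CCCCC` gives 47000 nM on this read-out
Compound 3 `CCCCCCCCCC(O)C#CC#CC(O)CCCCC` gives 12000 nM on this read-out

Compound 3 has the lower of the two true numbers, and its 12000 nM lies clearly apart from compound 2 at 47000 nM in this assay on this read-out. Compound 4 `CCCCCCCCCC(O)C#CC#CC(O)CC(C)C` differs from compound 3 at one place: isopropyl in place of butyl on a saturated chain carbon, two bonds along the chain from an oxygen on a saturated carbon and a triple-bonded carbon is the change. Isopropyl stands in place of butyl on a saturated chain carbon, two bonds along the chain from an oxygen on a saturated carbon and a triple-bonded carbon. The nearest measured step is an at least 2.1-fold lower number from compound 1 to compound 2 (0.32 log units; beyond the scatter) where pentyl replaced hydrogen, and its size rests on the limit of > 100000 nM in this assay, at which 1 of the 3 values shown sits, as one end. Among the compounds with values here, no measured step exchanges one chain for another, so that step gives only a loose guide. A small rise at most is expected. The estimated step is a 1.3-fold higher number from compound 3 to compound 4 (0.10 log units; within the scatter) and no change beyond the scatter is expected. In this assay the estimate for compound 4 is 15000 nM with an expected range from 6000 nM to 35000 nM as its ends.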

Compound 4, half-maximal inhibitory concentration: > 50000 nM
Compound 4: a limit, no number; the forecaster's own chance of this, stated with the estimate: 3%; middle value at least 3.3-fold (0.52 log units) from the limit.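

In this assay, the chain end of compound 3 turns out not to be a neutral place for change: isopropyl in place of butyl gives an at least 4.1-fold higher number from compound 3 to compound 4 (0.61 log units; beyond the scatter). Within the data shown here, the only earlier step, an at least 2.1-fold lower number from compound 1 to compound 2 (0.32 log units; beyond the scatter), showed the number falling when a chain was added, while this one shows it rising when a chain end is altered. Compound 4 has a limit rather than a number, so the step gives only a lower bound on the true size of the change: the limit of > 50000 nM in this assay, at which 1 of the 4 values shown sits.

Isopropyl differs from butyl in both length and branching, and the compounds shown cannot tell these two apart, so a straight propyl chain or a longer chain at this place remains an open case. Going by these compounds, whether an amine on this chain end would bring the number back down also stays open.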